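This account rests on a few compounds, and the source may have more. Where it says the series, first, only, none or still open, it means among the compounds named here.

Measured in an ADME assay on HUVEC cells (Homo sapiens) for antiproliferative activity, read by resazurin assay, with a stated time of 72 h; a higher number here means a weaker inhibitor of growth, a lower number a stronger inhibitor of growth:
- compound 1 `CN(C)C1=NN(c2ccccc2)CN(c2ccccc2Cl)C1=O`: 34.5 ug/mL
- compound 2 `O=C1C(N2CCCCC2)=NN(c2ccc(Cl)cc2)CN1c1ccccc1Cl`: > 50 ug/mL (a limit, not a number)
- compound 3 `O=C1C(N2CCCCC2)=NN(c2ccccc2)CN1c1ccccc1Cl`: 24.7 ug/mL

Compound 2 has no exact value and stands at the limit of > 50 ug/mL in this assay, at which 1 of the 3 values shown sits. Compound 4 `CN(C)C1=NN(c2ccc(Cl)cc2)CN(c2ccccc2Cl)C1=O`, not yet measured, keeps the 4-chlorophenyl group of compound 2 and departs from it by one exchange: dimethylamino in place of piperidin-1-yl on a carbon with a double bond to nitrogen. In words, dimethylamino stands in place of piperidin-1-yl on a carbon with a double bond to nitrogen.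

Going by the values given here, two measured steps bear on this. The same pair of groups is exchanged, read in the opposite direction and with hydrogen in place of chloro on the aromatic carbon, in a 1.4-fold lower number from compound 1 to compound 3 (0.15 log units; within the scatter). That step gives no sign that the exchange matters in this assay. The other relevant step is an at least 2.0-fold lower number from compound 2 to compound 3 (0.30 log units; that floor lies within the scatter), whose floor also offers no firm measure of what the chloro contributes, though it does leave the chloro-bearing compound 2 at the assay limit. No step beyond the scatter is therefore expected for the exchange itself, and compound 4 is expected to stay weak, quite possibly reported only as a limit.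

The expected change is a step that the limit leaves unreadable from compound 2 to compound 4. For compound 4 the estimated value is 60 ug/mL. The expected range for compound 4 runs from 35 ug/mL to 100 ug/mL.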

Compound 4, concentration for 50% growth inhibition in the HUVEC assay: 16.1 ug/mL
Estimate against measurement, compound 4: 3.7-fold (0.57 log units) above; the whole stated range lies above it.
By their numbers in the HUVEC assay, from the lowest: compounds 4, 3 and 1 (each within the scatter of the next, the first and the last beyond it). At a limit, above all of these: compound 2.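

In the HUVEC assay compound 2 gives > 50 ug/mL as a limit, not a number. In the HUVEC assay, dimethylamino in place of piperidin-1-yl is no longer a silent exchange when the 4-chlorophenyl group is present, giving an at least 3.1-fold lower number from compound 2 to compound 4 (0.49 log units; beyond the scatter), so the size of the step depends on the core that carries it: the same change on two cores in the HUVEC assay, a 1.4-fold lower number (0.15 log units; within the scatter) from compound 1 to compound 3 and an at least 3.1-fold higher number (0.49 log units; beyond the scatter) from compound 4 to compound 2, at least 4.3-fold (0.63 log units) apart, beyond the scatter of two such steps The chloro depends on its partner in the same way, for with dimethylamino in place it gives a 2.1-fold lower number from compound 1 to compound 4 (0.33 log units; beyond the scatter), whereas with piperidin-1-yl in place its step runs the other way: the same change on two cores in the HUVEC assay, an at least 2.0-fold lower number (0.30 log units; that floor lies within the scatter) from compound 2 to compound 3 and a 2.1-fold higher number (0.33 log units; beyond the scatter) from compound 4 to compound 1, at least 4.3-fold (0.63 log units) apart, beyond the scatter of two such steps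

In a physicochemical assay for lipophilicity, read by HPLC, measured as octanol-water partition (on this read-out lower numbers stand for lower lipophilicity and higher numbers for higher lipophilicity), compound 2 gives 5 and compound 4 gives 4.2 on the same scale. Going by these compounds, whether the lower lipophilicity that accompanies the exchange accounts for the step in growth inhibition stays open, as the two values alone cannot settle it: the measured partition coefficient of compound 2, 5, and of compound 4, 4.2, a number 0.80 log units lower (beyond the scatter) Also open is whether this dependence extends to other cyclic amines such as pyrrolidin-1-yl or morpholin-4-yl, or to a fluoro or methoxy group in place of the chloro on the phenyl ring.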